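This account rests on a few compounds, and the source may have more. Where it says the series, first, only, none or still open, it means among the compounds named here.

Three measured compounds share one core. Compound 1 `NC(=S)N1N=C(c2ccc(N3CCCCC3)cc2)CC1c1ccc(Cl)cc1` carries a thiocarbamoyl group on the ring nitrogen, and in a functional assay on A549 cells (Homo sapiens) for antiproliferative activity, read by MTT assay, with a stated time of 72 h (a higher number here means a weaker inhibitor, a lower number a stronger inhibitor), compound 1 gives 33800 nM. Compound 2 `Clc1ccc(C2CC(c3ccc(N4CCCCC4)cc3)=NN2c2nc(-c3ccccc3)cs2)cc1` has a phenyl-substituted thiazole in that place and gives 64200 nM; the change reads a 1.9-fold higher number from compound 1 to compound 2 (0.28 log units; within the scatter). Compound 3 `Fc1ccc(-c2csc(N3N=C(c4ccc(N5CCCCC5)cc4)CC3c3ccc(Cl)cc3)n2)cc1` adds a fluoro to that phenyl and gives 70200 nM; from compound 1 this is a 2.1-fold higher number from compound 1 to compound 3 (0.32 log units; beyond the scatter), and from compound 2 it is a 1.1-fold higher number from compound 2 to compound 3 (0.04 log units; within the scatter). Compound 3 therefore gives the largest of the three numbers, but the gap to compound 2 lies within the usual scatter, so those two cannot be told apart; only compound 1 stands apart beyond the scatter.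

Compound 4 `Clc1ccc(-c2csc(N3N=C(c4ccc(N5CCCCC5)cc4)CC3c3ccc(Cl)cc3)n2)cc1` differs from compound 3 by chloro in place of fluoro on an aromatic carbon. Among the compounds with values here, the step that bears most on this is the one from compound 2 to compound 3, where a fluoro entered the same position and nothing beyond the scatter followed. Swapping one halogen for another at that distant position is expected to change little, so compound 4 is expected to show a 1.1-fold higher number from compound 3 to compound 4 (0.03 log units; within the scatter), no step beyond the scatter. Compound 4 is thus estimated at 75000 nM, with a likely range from 35000 nM to 160000 nM.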

Compound 4, half-maximal inhibitory concentration: 46400 nM
Compound 4: the middle estimate sits 1.6-fold (0.21 log units) above what was measured; low and high end bracket the measured number.
By their numbers in this assay, from the lowest: compounds 1, 4, 2 and 3 (each within the scatter of the next, the first and the last beyond it).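

With chloro now at this spot on the six-membered aromatic ring, a 1.5-fold lower number from compound 3 to compound 4 (0.18 log units; within the scatter) and a 1.4-fold lower number from compound 2 to compound 4 (0.14 log units; within the scatter) both stay within the scatter, so hydrogen, fluoro and chloro cannot be told apart here in this assay. The result also softens the earlier reading of the group on the ring nitrogen: a 1.4-fold higher number from compound 1 to compound 4 (0.14 log units; within the scatter) lies within the scatter, while a 2.1-fold higher number from compound 1 to compound 3 (0.32 log units; beyond the scatter) lay only just beyond it, so exchanging the thiocarbamoyl group for a 4-aryl-1,3-thiazol-2-yl group gives a step beyond the scatter with fluoro on the aryl ring but not with chloro. No measurement shown here speaks to why these numbers sit so close together.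

The compounds shown cover only hydrogen and two halogens at this position, so it remains open whether a larger or quite different group there, such as a methoxy, an amine or a carboxylic acid, would give a step beyond the scatter. Going by these compounds, it also remains open whether this position would respond any differently if the 1,3-thiazol-2-yl link to the shared core were replaced by another ring.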